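The compounds below may be only part of what the source reports. "The series", "measured", "known", "first", "only" and "open" are said of these compounds alone.

In an ADME assay on MCF-10A cells (Homo sapiens) for inhibition, with a stated time of 48 h (on this read-out higher numbers stand for weaker inhibition and lower numbers for stronger inhibition), compound 3 `Cc1cccc(-c2noc([C@@H]3CCCN3C(=O)Nc3ccc(Cl)cc3)n2)c1` gives > 50000 nM as a limit of the assay. Compound 1 `N#Cc1ccc(NC(=O)N2CCC[C@H]2c2nc(-c3ccccc3)no2)cc1` gives > 50000 nM as a limit as well. Compound 2 `O=C(Nc1ccc(OC(F)(F)F)cc1)N1CCC[C@H]1c1nc(-c2ccccc2)no1` gives > 50000 nM as a limit too. The set therefore shows the limit of > 50000 nM in this assay, at which 3 of the 3 values shown sit, and no exact number. Compound 4 `O=C(Nc1ccc(Cl)cc1)N1CCC[C@H]1c1nc(-c2ccc(F)cc2)no1` carries 4-fluorophenyl in place of 3-methylphenyl on an aromatic carbon and otherwise matches compound 3. Within the data shown here, the one measured step that the two limits leave unreadable from compound 1 to compound 2 concerns other groups and has no readable size to carry over. No shift beyond the scatter is expected in this assay and the estimated step is a number no higher from compound 3 to compound 4 (the limit leaves the size open) in size. Compound 4 is estimated at 50000 nM with an expected range from 25000 nM to 100000 nM and will probably be reported only as a limit.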

Compound 4, half-maximal inhibitory concentration: > 50000 nM
Compound 4 ended at the assay's limit (the forecaster's own chance of this, stated with the estimate: 85%); the middle value sits exactly at the limit.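

Compound 3 and compound 4 both stand at a limit of the assay, and the step between them cannot be read. The compounds shown leave open how strongly any of them inhibits in this assay, with no exact number among them: the limit of > 50000 nM in this assay, at which 4 of the 4 values shown sit.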